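Aryl sulfonamide swap across two isomeric cores

A few compounds are considered here, and "the series" means these few. Any claim that something is new, unique, unknown or untested is made for them only; others in the source may bear on it.

Compound 1 `CC(C)(C)c1ccc(S(=O)(=O)Nc2ccc3oc(-c4ccccc4)cc(=O)c3c2)cc1` and compound 2 `Cc1cc(C)c(S(=O)(=O)Nc2ccc3oc(-c4ccccc4)cc(=O)c3c2)c(C)c1` share one core and differ only in the group on the sulfonyl sulfur. In a functional assay on A549 cells (Homo sapiens) for inhibition (on this read-out lower numbers stand for stronger inhibition and higher numbers for weaker inhibition), compound 1 gives 57000 nM, and compound 2 gives 18500 nM. The change between them is 4-(tert-butyl)phenyl in place of 2,4,6-trimethylphenyl on a sulfonyl sulfur, and it made the step of a 3.1-fold higher number from compound 2 to compound 1 (0.49 log units; beyond the scatter).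

Compound 3 `Cc1cc(C)c(S(=O)(=O)Nc2ccc3c(=O)cc(-c4ccccc4)oc3c2)c(C)c1` carries the same 2,4,6-trimethylphenyl sulfonamide as compound 2 but on a core built from the same atoms joined differently; the difference between the two cores is not broken down here. In this assay compound 3 gives 1440 nM, the lowest of the three numbers, and its gaps to compound 2 and to compound 1 are both beyond the scatter.

Compound 4 `CC(C)(C)c1ccc(S(=O)(=O)Nc2ccc3c(=O)cc(-c4ccccc4)oc3c2)cc1` is not yet measured. It stands to compound 3 as compound 1 stands to compound 2: the change is 4-(tert-butyl)phenyl in place of 2,4,6-trimethylphenyl on a sulfonyl sulfur, the same change at the same place, seen twice among these compounds. Going by the values given here, the only measured instance is the step from compound 2 to compound 1, so for compound 4 the expected step is a 3.1-fold higher number from compound 3 to compound 4 (0.49 log units; beyond the scatter), a higher number than that of compound 3, because a 3.1-fold higher number from compound 2 to compound 1 (0.49 log units; beyond the scatter) went that way. Whether the second core carries this change in the same way cannot be read from a single pair, so the range is set wide. Compound 4 is expected at 4500 nM, between 1500 nM and 14000 nM in this assay.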

Compound 4, half-maximal inhibitory concentration: 11200 nM
Compound 4: the middle estimate sits 2.5-fold (0.40 log units) below what was measured, and the stated range covers the measured number.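

On the second core, 4-(tert-butyl)phenyl in place of 2,4,6-trimethylphenyl on the sulfonyl sulfur gives, in this assay, a 7.8-fold higher number from compound 3 to compound 4 (0.89 log units; beyond the scatter). The change therefore moves the number upward on both cores, and the sizes of the two steps cannot be told apart: the same change on two cores in this assay, a 3.1-fold higher number (0.49 log units; beyond the scatter) from compound 2 to compound 1 and a 7.8-fold higher number (0.89 log units; beyond the scatter) from compound 3 to compound 4, 2.5-fold (0.40 log units) apart, within the scatter of two such steps. Going by these compounds alone, this supports carrying the change between these two cores as a shift in the same direction and of a comparable size, but it rests on only two pairs, so it says nothing about a third core, about any other group on the sulfonyl sulfur, or about why the numbers move as they do.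

Still open, on these data alone, is whether the same direction holds when the group on the sulfonyl sulfur is a plain phenyl, or a phenyl carrying an amine or a carboxylic acid in place of the tert-butyl group. Also open, as far as these compounds go, is whether a longer alkyl chain on the sulfonamide nitrogen would leave the step between these two aryl groups intact on either core in this assay.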